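The source may report more compounds than this note shows. Statements on the series, on what has been measured and on what is new or still open speak of the compounds shown alone.

In a functional assay on NCI-H661 cells (Homo sapiens) for antiproliferative activity, read by MTT assay, with a stated time of 72 h (a higher number here means a weaker inhibitor, a lower number a stronger inhibitor), compound 1 (`Cc1ccc(-c2noc(CCCCCCC(=O)Nc3ccccc3N)n2)cc1`) gives 410 nM and compound 2 (`O=C(CCCCCCc1nc(-c2ccccc2)no1)C(F)(F)F`) gives 520 nM so the two stand within the scatter of each other. For the measured compounds named here, no two measured compounds differ in one place alone, so no measured step is available as a guide to what follows. Compound 3 (`Cc1ccc(-c2noc(CCCCCCC(=O)C(F)(F)F)n2)cc1`) differs from compound 2 by a single change (methyl in place of hydrogen on an aromatic carbon): methyl in place of hydrogen on an aromatic carbon, which turns phenyl to 4-methylphenyl. Starting from compound 2 at 520 nM no step beyond the scatter is expected in this assay and neither direction is favoured. The estimated move (a 1.2-fold lower number from compound 2 to compound 3 (0.06 log units; within the scatter)) is correspondingly small. For compound 3 the expected value is 450 nM with an estimated range from 200 nM to 1000 nM once it is measured.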

Compound 3, half-maximal inhibitory concentration: 18700 nM
For compound 3 the middle estimate is 42-fold (1.62 log units) below the measured one; measured number outside the range, above it.
By their numbers in this assay, from the lowest: compounds 1 and 2 (each within the scatter of the next); then compound 3.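

In this assay, adding one methyl on an aromatic carbon, para to a large group, gives a 36-fold higher number from compound 2 to compound 3 (1.56 log units; beyond the scatter), so this position is sensitive when trifluoromethyl sits on the carbonyl carbon. The 4-methylphenyl group is also present in compound 1, and the change at the other end of the chain, trifluoromethyl in place of (2-aminophenyl)amino, gives a 46-fold higher number from compound 1 to compound 3 (1.66 log units; beyond the scatter), so the high number of compound 3 does not follow from the methyl alone but appears only with trifluoromethyl at that carbonyl. No measurement shown here bears on why either step is so large.

On these data alone, it remains open whether replacing the methyl with hydrogen would change the number when (2-aminophenyl)amino sits on the carbonyl carbon. As far as these compounds go, it is also open whether a chlorine or a methoxy group at this position would behave as the methyl does.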